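The source may hold more compounds than are shown below. What is called first, only, known or untested is meant among the compounds shown, and "the series" means these compounds.

Compound 1 `Cc1c(F)cc(C(=O)NC2CCCCCC2)c(=O)n1Cc1ccc(F)cc1`: > 10000 nM
Compound 2 `COc1ccc(-c2cc(C(=O)NC3CCCCCC3)c(OCc3ccc(F)cc3)nc2C)cc1`: > 10000 nM

In an assay on U-937 cells for inhibition of Fatty-acid amide hydrolase 1 (Homo sapiens), read by scintillation counting, with a stated time of 15 min (on this read-out higher numbers stand for weaker inhibition and lower numbers for stronger inhibition), compound 1 reaches only the limit of the assay, > 10000 nM. Compound 2, tested in this assay, likewise gives only the assay limit, > 10000 nM. Neither value is a number, so compound 1 stands at the ceiling of what the assay can report, as both measured compounds do (the limit of > 10000 nM in this assay, at which 2 of the 2 values shown sit). For the measured compounds named here, no step between measured compounds can be drawn from two limits. Compound 3 `Cc1c(-c2ccc(F)cc2)cc(C(=O)NC2CCCCCC2)c(=O)n1Cc1ccc(F)cc1` has not yet been measured; it differs from compound 1 by 4-fluorophenyl in place of fluoro on an aromatic carbon. With both measured compounds sitting at the limit, there is no measured change to lean on. The step from compound 1 to compound 3 is expected to be a step that the limit leaves unreadable from compound 1 to compound 3, that is, none clearly beyond the scatter. Compound 3 is therefore estimated at 12000 nM, within a range from 2000 nM to 60000 nM.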

Compound 3, half-maximal inhibitory concentration: 530 nM
Compound 3: the middle estimate sits 23-fold (1.35 log units) above what was measured, and the stated range ends above it.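

In this assay the change on this aromatic carbon, ortho to a methyl group and two atoms from the ring nitrogen, gives an at least 18-fold lower number from compound 1 to compound 3 (1.27 log units; beyond the scatter) with 4-fluorophenyl in place of fluoro. For the compounds shown here, this position, which the earlier compounds left unreadable, therefore responds to what stands on it, and the entering six-membered aromatic ring goes with the only value shown that is a number and not a limit of the assay. The full size of the step cannot be read, since compound 1 stands at a limit, as does compound 2: the limit of > 10000 nM in this assay, at which 2 of the 3 values shown sit. As far as these compounds go, whether the fluorine on the entering ring has any share in the step stays open. So does what an unsubstituted phenyl or a morpholine on this carbon would give.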